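Methyl on the Benzylamine Nitrogen: What to Expect

The compounds below may be only part of what the source reports. "The series", "measured", "known", "first", "only" and "open" are said of these compounds alone.

This account concerns cytotoxicity, measured in an ADME assay on Vero cells (Chlorocebus sabaeus) for cytotoxicity, read by MTT assay, with a stated time of 48 h; a lower number here means a stronger inhibitor, a higher number a weaker inhibitor. Compound 1, `O=c1cc(NCc2ccccc2)sc2c([N+](=O)[O-])cc(C(F)(F)F)cc12`, is the starting point. In this assay compound 1 gives > 64 ug/mL, which is a limit of the assay and not a measured number. Two further compounds on the same core have also been tested. Compound 2, `O=c1nc(NCc2ccc3c(c2)OCCO3)oc2c([N+](=O)[O-])cc(C(F)(F)F)cc12`, gives 25.3 ug/mL in this assay. Compound 3, `C[C@H]1COC2(CCN(c3nc(=O)c4cc(C(F)(F)F)cc([N+](=O)[O-])c4s3)CC2)O1`, gives > 64 ug/mL in this assay, again a limit and not a number. Compound 1 therefore stands at the limit of > 64 ug/mL in this assay, at which 2 of the 3 values shown sit, so no measured value separates it from compound 3, and only compound 2 returns a number at all.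

Compound 4, `CN(Cc1ccccc1)c1cc(=O)c2cc(C(F)(F)F)cc([N+](=O)[O-])c2s1`, has not yet been measured. It differs from compound 1 by a single change: methyl in place of hydrogen on a nitrogen on an aromatic ring. Within the data shown here, no pair of measured compounds shows this particular change, so its effect can only be expected, not read off. Compound 1 sits at a limit, > 64 ug/mL, in this assay. The step from compound 1 to compound 4 is expected to be an at least 1.0-fold lower number from compound 1 to compound 4 (0.02 log units; that floor lies within the scatter), that is, no shift beyond the usual scatter. Compound 4 is accordingly estimated to give 60 ug/mL, within a range of 25 ug/mL to 130 ug/mL.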

Compound 4, half-maximal inhibitory concentration: > 64 ug/mL
Compound 4 gave a limit, no number; the forecaster's own chance of this, stated with the estimate: 60%; middle value at least 1.0-fold (0.02 log units) from the limit.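

In this assay compound 4 gives > 64 ug/mL, a limit of the assay and not a number. Compound 1 also stands at a limit, so no step can be read between compound 1 and compound 4: the limit of > 64 ug/mL in this assay, at which 3 of the 4 values shown sit. The compounds shown leave open whether methyl in place of hydrogen on this nitrogen changes cytotoxicity at all.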